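Swapping a pyridinyl for a cyclopropyl on a triazole core

The source may hold more compounds than are shown below. What is called first, only, known or untested is meant among the compounds shown, and "the series" means these compounds.

Of the compounds shown here, three from this series have been tested in a functional assay on the whole organism (strain CF-1) for inhibition, with Mus musculus as the target; on this read-out lower numbers stand for an effect already at smaller amounts and higher numbers for an effect only at larger amounts of compound. Compound 1, with the structure `Cc1nnc(CN)n1-c1ccc(Cl)cc1C(O)c1ccccc1`, gives 71 mg/kg. Compound 2, with the structure `CCNCc1nnc(C)n1-c1ccc(Cl)cc1C(=O)c1ccccc1`, gives 45 mg/kg. Compound 3 has the structure `CN(C)Cc1nnc(-c2ccncc2)n1-c1ccc(Cl)cc1C(=O)c1ccccc1Cl`. For compound 3 this assay reports only a limit, > 100 mg/kg, not a measured number; it is one of the cases captured by the limit of > 100 mg/kg in this assay, at which 1 of the 3 values shown sits. Compound 3 therefore stands at the far end of the values shown, where an effect, if any, needs the largest amount of compound.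

The untested compound 4 has the structure `CN(C)Cc1nnc(C2CC2)n1-c1ccc(Cl)cc1C(=O)c1ccccc1Cl`. It differs from compound 3 in a single place: cyclopropyl in place of pyridin-4-yl on an aromatic carbon. Among the compounds with values here, no pair of the measured compounds differs in just one spot, so there is no measured step to lean on for the size or direction of this change. With compound 3 sitting at a limit, the step from compound 3 to compound 4 is expected to be small or none beyond the scatter, as expressed by a step that the limit leaves unreadable from compound 3 to compound 4. For compound 4 the estimated value in this assay is 110 mg/kg, with a likely range from 40 mg/kg to 300 mg/kg, and a fair chance that only a limit is again reported.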

Compound 4, dose for half-maximal effect: 79 mg/kg
Beside the measured number, compound 4's estimate is 1.4-fold (0.14 log units) above it; the range from low to high includes it.
By their numbers in this assay, from the lowest: compounds 2, 1 and 4 (each within the scatter of the next). At a limit, above all of these: compound 3.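

In this assay, cyclopropyl in place of pyridin-4-yl on this aromatic carbon of the core gives an at least 1.2-fold lower number from compound 3 to compound 4 (0.10 log units; that floor lies within the scatter). Compound 4 gives a measured number, 79 mg/kg, so this place, between two ring nitrogen atoms, can carry a small three-membered ring of carbon only and still show an effect that can be put on the scale, which the pyridin-4-yl compound does not offer. The real size of the step could be small or much larger, and it cannot be pinned down because compound 3 gives only a limit and no measured number: the limit of > 100 mg/kg in this assay, at which 1 of the 4 values shown sits.

The change swaps several things at once, the ring size, the aromatic ring and the ring nitrogen, so the compounds shown cannot say which of these counts. On these data alone, a phenyl ring at this place, with the rest of compound 4 unchanged, would separate the ring nitrogen from the ring itself, and an open chain such as propyl would show whether a ring is needed here at all, yet what either would give stays open.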